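The source may report more compounds than this note shows. Statements on the series, on what has been measured and on what is new or still open speak of the compounds shown alone.

In a functional assay on HT29-AK cells (Homo sapiens) for cytotoxicity, read by MTT assay, with a stated time of 48 h (a lower number here means a stronger inhibitor, a higher number a weaker inhibitor), compound 1 `COc1ccc(Nc2nc(-c3cccc(F)c3)nc3ccc(F)cc23)cc1` gives 42300 nM. Compound 2 `Oc1ccc(Nc2nc(-c3cccc(F)c3)nc3ccc(F)cc23)cc1` gives > 50000 nM, which is a limit of the assay and not a number. That reading is the limit of > 50000 nM in this assay, at which 1 of the 2 values shown sits, so compound 2 has no exact place on the scale. The next structure, compound 3 `Cc1cccc(Nc2nc(-c3cccc(F)c3)nc3ccc(F)cc23)c1`, carries 3-methylphenyl in place of 4-hydroxyphenyl on a nitrogen on an aromatic ring. Going by the values given here, the only measured guide is the step of an at least 1.1-fold higher number from compound 1 to compound 2 (0.07 log units; that floor lies within the scatter), made by hydrogen in place of methyl on an oxygen on an aromatic ring. That step is small, but it changes less than the new swap does, so it offers only a loose guide. No step beyond the scatter is therefore expected in this assay, in either direction. The expected step is an at least 1.3-fold lower number from compound 2 to compound 3 (0.11 log units; that floor lies within the scatter). For compound 3 the estimated value is 38000 nM, with an expected range from 14000 nM to 70000 nM.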

Compound 3, half-maximal inhibitory concentration: > 50000 nM
Compound 3 ended at the assay's limit; the forecaster's own chance of this, stated with the estimate: 35%; at least 1.3-fold (0.11 log units) between middle value and limit.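

In this assay, compound 3 gives > 50000 nM, which is a limit of the assay and not a number. Set against the one exact value in the series, replacing 4-methoxyphenyl with 3-methylphenyl on this nitrogen gives an at least 1.1-fold higher number from compound 1 to compound 3 (0.07 log units; that floor lies within the scatter), so a ring with no hydrogen-bond donor or acceptor shows no change that can be told apart from the scatter; the step between the two compounds that both sit at the limit cannot be read. The position has now taken three different rings without giving a number clearly lower than the one for compound 1, and the readings crowd at the top of the scale: the limit of > 50000 nM in this assay, at which 2 of the 3 values shown sit.

On these data alone, whether an amine or a carboxylic acid on this ring would bring a clearly lower number remains open. So does the effect of a longer chain in place of the methyl.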